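Swapping ethyl for 1,1-difluoroethyl on the shared core

The source may report more compounds than this note shows. Statements on the series, on what has been measured and on what is new or still open speak of the compounds shown alone.

Measured compounds:
- compound 1 `COCc1nc2nc(C)cc(Nc3ccc(C(F)(F)F)cc3)n2n1`: 6.7 mL.min-1.g-1
- compound 2 `CCc1nc2nc(C)cc(Nc3cccc(Cl)c3)n2n1`: 78.3 mL.min-1.g-1
- compound 3 `Cc1cc(Nc2ccc(S(F)(F)(F)(F)F)cc2)n2nc(C3CC3)nc2n1`: < 5 mL.min-1.g-1

In an in vitro ADME assay on microsomes from liver (Homo sapiens) for metabolic stability (on this read-out lower numbers stand for slow clearance and higher numbers for fast clearance), compound 2 gives 78.3 mL.min-1.g-1, the highest of the two numbers shown; compound 1 sits a good deal lower, beyond the usual scatter. For compound 3 the assay reports only a limit, (the limit of < 5 mL.min-1.g-1 in this assay, at which 1 of the 3 values shown sits), not a number. Compound 4 `Cc1cc(Nc2cccc(Cl)c2)n2nc(C(C)(F)F)nc2n1` has not yet been measured. It differs from compound 2 in one place: 1,1-difluoroethyl in place of ethyl on an aromatic carbon. Among the measured compounds shown here, no measured pair shows this change on its own, so the size of the step is uncertain. Still, compound 4 is expected to clear more slowly than compound 2, with the step of a 3.9-fold lower number from compound 2 to compound 4 (0.59 log units; beyond the scatter) going downward beyond the scatter. The estimate for compound 4 in this assay is 20 mL.min-1.g-1, with a range from 6 mL.min-1.g-1 to 60 mL.min-1.g-1.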

Compound 4, intrinsic clearance in microsomes in the Homo sapiens assay: 44.4 mL.min-1.g-1
Estimate against measurement, compound 4: 2.2-fold (0.35 log units) below; measured number inside the range.
By their numbers in the Homo sapiens assay, from the lowest: compound 1; then compounds 4 and 2 (each within the scatter of the next). At a limit, below all of these: compound 3.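

In the Homo sapiens assay, 1,1-difluoroethyl in place of ethyl on this aromatic carbon gives a 1.8-fold lower number from compound 2 to compound 4 (0.25 log units; within the scatter), so this single-change pair cannot be told apart on clearance. In a physicochemical assay for solubility, at pH 6.5 (on this read-out higher numbers stand for higher solubility and lower numbers for lower solubility), compound 2 gives 170000 nM and compound 4 gives 77000 nM, a modest step that lies beyond the usual scatter. At this position, then, the swap shows up in solubility but not clearly in clearance.

From the compounds shown here alone, what a hydroxyl group or a nitrile at this position would do to either read-out stays open. So does whether the swap behaves the same way on a compound other than compound 2.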